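Replacing the ester chain in a microsomal stability series

A few compounds are considered here, and "the series" means these few. Any claim that something is new, unique, unknown or untested is made for them only; others in the source may bear on it.

Among the measured compounds shown here, compound 2 `CCOc1cc(NC(=O)C2(NC(=O)c3ccc4c(C5CCCC5)c(-c5ncc(Cl)cn5)n(C)c4c3)CCC2)ccc1/C=C/C(=O)OCCOCCOC` gives the only number in this set: in an ADME assay (liver) for pharmacokinetics, with Liver microsome (Homo sapiens) as the target, using microsomes (a lower number here means that the compound disappears faster, a higher number that the compound lasts longer), compound 2 shows 0.85 h. Compound 1 `CCOC(=O)/C=C/c1ccc(NC(=O)C2(NC(=O)c3ccc4c(C5CCCC5)c(-c5ncc(Cl)cn5)n(C)c4c3)CCC2)cc1OCC` reaches only a limit of the assay, > 5 h, which is the limit of > 5 h in this assay, at which 1 of the 2 values shown sits. Compound 3 `CCOc1cc(NC(=O)C2(NC(=O)c3ccc4c(C5CCCC5)c(-c5ncc(Cl)cn5)n(C)c4c3)CCC2)ccc1/C=C/C(=O)OCC(=O)OCc1ccc(Cl)cc1` differs from compound 2 by ((4-chlorobenzyl)oxy)carbonyl in place of (2-methoxyethoxy)methyl on a saturated chain carbon bound to an oxygen next to a carbonyl group. For the measured compounds named here, the one measured step, an at least 5.8-fold lower number from compound 1 to compound 2 (0.76 log units; beyond the scatter), also changed this ester chain and is the only guide; the change here is of a different kind. Compound 3 is therefore expected to give 0.6 h, between 0.2 h and 2 h, an expected step of a 1.4-fold lower number from compound 2 to compound 3 (0.15 log units; within the scatter) within the scatter.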

Compound 3, half-life: 5.62 h
Estimate against measurement, compound 3: 9.4-fold (0.97 log units) below; the whole stated range lies below it.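

In this assay, the ester chain can move the half-life up as well as down: ((4-chlorobenzyl)oxy)carbonyl in place of (2-methoxyethoxy)methyl gives a 6.6-fold higher number from compound 2 to compound 3 (0.82 log units; beyond the scatter). The entering group has more heavy atoms than the one leaving, so a bigger group at this place does not by itself bring a lower number. Compound 1 gives only a limit, so its step to compound 3 cannot be read: the limit of > 5 h in this assay, at which 1 of the 3 values shown sits.

The compounds shown leave open which part of the entering group, the carbonyl or the chlorinated ring, carries the rise. As far as these compounds go, how a carboxylic acid in place of the ester chain would behave also stays open.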